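The source may report more compounds than this note shows. Statements on the series, on what has been measured and on what is new or still open speak of the compounds shown alone.

Working notes on the series.

Three compounds carry a number or a limit in an assay on membranes from brain for binding affinity to Monoglyceride lipase (Mus musculus), read by fluorescence, with stated times of 1 h and 30 min; a higher number here means a weaker inhibitor, a lower number a stronger inhibitor. Compound 1 `Cc1cnn(C(=O)NCc2ccc(OC(c3ccccc3)c3ccccc3)cc2)c1` gives in this assay only a limit, > 100000 nM, not a number. Compound 2 `Cc1cnn(C(=O)N2CCN(C(c3ccc(OCc4ccccc4)cc3)c3ccc(OCc4ccccc4)cc3)CC2)c1` gives 2100 nM in this assay. Among the compounds with values here, compound 3 `O=C(N1CCN(C(c2ccc(OCc3ccccc3)cc2)c2ccc(OCc3ccccc3)cc2)CC1)n1cccn1` gives 3900 nM in this assay, the highest of the two numbers, with compound 2 nearest; the single step between them, a 1.9-fold higher number from compound 2 to compound 3 (0.27 log units; within the scatter), is hydrogen in place of methyl on an aromatic carbon and lies within the scatter.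

Compound 4 `N#Cc1cnn(C(=O)N2CCN(C(c3ccc(OCc4ccccc4)cc3)c3ccc(OCc4ccccc4)cc3)CC2)c1` is not yet measured in this assay. It differs from compound 3 by cyano in place of hydrogen on an aromatic carbon. Within the data shown here, the only measured step that touches the same carbon is a 1.9-fold higher number from compound 2 to compound 3 (0.27 log units; within the scatter), where removing a methyl moved the number by less than the scatter; it runs in the opposite sense to the present change and carries a different group, so it bears on it only loosely. Among the measured compounds shown here, no measured step shows a cyano at any position. For the measured compounds named here, from the one step at hand the expected change for compound 4 is small, a 1.6-fold lower number from compound 3 to compound 4 (0.19 log units; within the scatter), with no clear direction beyond the scatter. Compound 4 is therefore estimated at 2500 nM in this assay, between 600 nM and 10000 nM.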

Compound 4, half-maximal inhibitory concentration: 20 nM
For compound 4 the middle estimate is 130-fold (2.10 log units) above the measured one; measured number below the stated range.
By their numbers in this assay, from the lowest: compound 4; then compounds 2 and 3 (each within the scatter of the next). At a limit, above all of these: compound 1.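

In this assay the aromatic carbon of the five-membered aromatic ring, which seemed insensitive while only hydrogen and methyl had been compared there, responds strongly to cyano, with a 200-fold lower number from compound 3 to compound 4 (2.29 log units; beyond the scatter) and with a 110-fold lower number from compound 2 to compound 4 (2.02 log units; beyond the scatter) on the same shared core. Since compound 2 and compound 3 lie within the scatter of each other, filling this carbon does not in itself bring the gain, which appears here only with cyano and not with methyl. The entering group is small, two heavy atoms and no ring, so among the compounds shown this one position on the ring carries the largest single-place step, and the earlier pair gave no sign of it.

Going by these compounds, how a carboxylic acid, a primary amide or an aminomethyl group on this carbon would read in this assay stays open, as does whether 4-cyano-1H-pyrazol-1-yl brings a similar gain on another core, such as that of compound 1. Nothing among the data at hand gives a reason for the size of this change.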